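The compounds below may be only part of what the source reports. "The series", "measured", "known", "first", "only" and "open" are said of these compounds alone.

Measured in a functional assay on COR-L23 cells (Homo sapiens) for antiproliferative activity, read by CellTiter-Glo, with a stated time of 4 days; on this read-out lower numbers stand for stronger inhibition and higher numbers for weaker inhibition:
- compound 1 `Nc1ccc(CNC(=O)Nc2ccc(CN3C(=O)c4ccccc4C3=O)cc2)cn1`: 57 nM
- compound 2 `O=C(/C=C/c1cccnc1)Nc1ccc(CN2C(=O)c3ccccc3C2=O)cc1`: 2000 nM
- compound 3 `O=C(Nc1ccc(CN2C(=O)c3ccccc3C2=O)cc1)[C@H]1C[C@@H]1c1cccnc1`: 35 nM

Compound 3 and compound 1 sit together at the low end of these numbers, with compound 2 far from both. The steps show this: a 1.6-fold lower number from compound 1 to compound 3 (0.21 log units; within the scatter), and a 57-fold lower number from compound 2 to compound 3 (1.76 log units; beyond the scatter).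

Next is compound 4 `O=C(Nc1ccc(CN2C(=O)c3ccccc3C2=O)cc1)[C@@H]1C[C@H]1c1cccnc1`, the mirror image of compound 3: the two compounds have the same atoms and bonds and differ only in configuration as drawn: 2 of 2 stereo elements differ (all stereocentres are inverted: mirror images); a stereocentre at a saturated ring carbon is drawn S in compound 3 and R in compound 4; a stereocentre at a saturated ring carbon is drawn S in compound 3 and R in compound 4.

For the measured compounds named here, no measured pair tests configuration directly. The nearest evidence is that changing the group on the carbonyl carbon can matter: a 35-fold higher number from compound 1 to compound 2 (1.55 log units; beyond the scatter). A step beyond the scatter in this assay is therefore expected, probably towards a higher number, though the data do not fix the direction. The expected step is a 4.3-fold higher number from compound 3 to compound 4 (0.63 log units; beyond the scatter). For compound 4 the estimated value is 150 nM, with an expected range of 10 nM to 2000 nM.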

Compound 4, half-maximal inhibitory concentration: > 10000 nM
Compound 4 ended at the assay's limit; the forecaster's own chance of this, stated with the estimate: 5%; middle value at least 66-fold (1.82 log units) from the limit.
By their numbers in this assay, from the lowest: compounds 3 and 1 (each within the scatter of the next); then compound 2. At a limit, above all of these: compound 4.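

Configuration alone at the 2-(pyridin-3-yl)cyclopropyl group on the carbonyl carbon gives an at least 280-fold higher number from compound 3 to compound 4 (2.45 log units; beyond the scatter), so this position depends on stereochemistry as well as on the choice of group: the fact that compounds 3 and 4 differ only in the configuration as drawn. The cyclopropyl group alone does not secure activity: with the inverted configuration it gives an at least 5.0-fold higher number from compound 2 to compound 4 (0.69 log units; beyond the scatter) against the 2-(pyridin-3-yl)ethenyl group and an at least 170-fold higher number from compound 1 to compound 4 (2.24 log units; beyond the scatter) against the ((6-aminopyridin-3-yl)methyl)amino group. The reading for compound 4 is a limit, not a number: the limit of > 10000 nM in this assay, at which 1 of the 4 values shown sits.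

Going by these compounds, how far past that limit compound 4 lies remains open. Also open, on these data alone, is whether a cyclobutyl ring in place of the cyclopropyl ring would show the same dependence on configuration.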